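Benzimidazole-piperazine amides: nitro to methyl on the benzoyl

The compounds below may be only part of what the source reports. "The series", "measured", "known", "first", "only" and "open" are said of these compounds alone.

Measured so far in an assay on isolated protein for inhibition of aldehyde dehydrogenase 1A1 (Homo sapiens), read by spectrophotometry, tested at 10 uM; a lower number here means less inhibition, a higher number more inhibition at the concentration tested (going by the name of the read-out):
compound 1 `Cc1cccc(Cn2c(CN3CCN(C(=O)c4ccc([N+](=O)[O-])cc4)CC3)nc3ccccc32)c1` gives 24.3%
compound 2 `O=C(C1CC1)N1CCN(Cc2nc3ccccc3n2Cc2ccccc2)CC1` gives 23.9%
compound 3 `O=C(C1CC1)N1CCN(Cc2nc3ccccc3n2Cc2ccc(Cl)cc2)CC1` gives 56.6%

Compound 1 stands second highest of the three numbers; its value and that of compound 2 lie within the scatter of one another, while compound 3 sits well above both. Among the measured compounds shown here, the single step, a number 32.7 percentage points higher from compound 2 to compound 3 (beyond the scatter), concerns the ring attached to the core nitrogen and not the amide side of the molecule.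

Compound 4 `Cc1ccc(C(=O)N2CCN(Cc3nc4ccccc4n3Cc3cccc(C)c3)CC2)cc1` is the unmeasured analogue of compound 1. The change is methyl in place of nitro on an aromatic carbon. For the measured compounds named here, no measured pair alters the amide-bound ring, so the step from compound 2 to compound 3 does not bear on this change and nothing indicates its direction. The expectation for this assay is therefore a step of about a number 0.7 percentage points higher from compound 1 to compound 4 (within the scatter), that is, none beyond the scatter.

Compound 4 is estimated at 25%, in the range 10% to 45%.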

Compound 4, a percentage reported as inhibition, at one concentration (the size of the read-out at that concentration, not a potency): 64.9%
The estimate for compound 4 lay 39.9 percentage points below the measured number, and the stated range ends below it.
By their numbers in this assay, from the lowest: compounds 2 and 1 (each within the scatter of the next); then compounds 3 and 4 (each within the scatter of the next).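

In this assay, the substituent on the ring of the amide side proves to matter: 4-methylphenyl in place of 4-nitrophenyl gives a number 40.6 percentage points higher from compound 1 to compound 4 (beyond the scatter). The amide side therefore responds to a single aromatic substituent, as the benzyl side did with the large a number 32.7 percentage points higher from compound 2 to compound 3 (beyond the scatter). No measurement shown here accounts for the new step.

The two end points cannot separate the loss of nitro from the gain of methyl, so a plain phenyl ring, or an amine, a methoxy group or a chlorine at the same carbon, would be needed to show which of the two carries the step. From the compounds shown here alone, whether the step holds with other groups on the benzyl ring, such as the 4-chlorobenzyl group of compound 3, also remains open.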